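Cytotoxicity notes on the bicyclic amine series

The source may hold more compounds than are shown below. What is called first, only, known or untested is meant among the compounds shown, and "the series" means these compounds.

Compound 1 `CCc1csc(CN[C@@H]2C[C@H]3C[C@@H]([C@H]2C)C3(C)C)c1` gives 25000 nM in an ADME assay on MDCK cells (Canis lupus familiaris) for cytotoxicity, read by microscopy, with a stated time of 48 h; on this read-out lower numbers stand for higher toxicity in this test and higher numbers for lower toxicity in this test.
Compound 2 `C[C@H]1[C@H](NCc2cncnc2)C[C@H]2C[C@@H]1C2(C)C` gives only the assay limit > 100000 nM, not a number.
Compound 3 `C[C@H]1[C@H](NCc2ccc(Br)s2)C[C@H]2C[C@@H]1C2(C)C` gives 43000 nM.

Among the two real numbers, compound 1 and compound 3 sit within the usual scatter of one another, so no order between them can be read; compound 2 stands apart only as a limit, and the limit of > 100000 nM in this assay, at which 1 of the 3 values shown sits, is the one such entry in the set.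

Compound 4 `C[C@H]1[C@H](NCc2cc(-c3ccsc3)cs2)C[C@H]2C[C@@H]1C2(C)C` is the next member and differs from compound 1 by thiophen-3-yl in place of ethyl on an aromatic carbon. Among the measured compounds shown here, the single measured step, an at least 2.3-fold lower number from compound 2 to compound 3 (0.36 log units; beyond the scatter), swaps the whole aromatic group on the saturated chain carbon bound to the amine nitrogen, so it shows that changing the aromatic part can move this read-out beyond the scatter, but it does not copy the present change, which keeps the thiophene of compound 1 and only enlarges what sits on it. For the measured compounds named here, no measured pair tests thiophen-3-yl against ethyl.

Going by the values given here, with no direct precedent, compound 4 is expected to stay near compound 1, with a step of no change at the digits printed from compound 1 to compound 4 (within the scatter) that is not expected to exceed the scatter. The estimate for compound 4 is 25000 nM, ranging from 8000 nM to 80000 nM.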

Compound 4, minimum cytotoxic concentration: 25000 nM
Compound 4: middle estimate and measured number agree at the digits printed; the measured number falls inside the stated range.
By their numbers in this assay, from the lowest: compounds 1, 4 and 3 (each within the scatter of the next). At a limit, above all of these: compound 2.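

Among the compounds shown here, on an aromatic carbon two ring bonds from the ring sulfur and two ring bonds from the ring atom that bears a large group, thiophen-3-yl in place of ethyl gives no change at the digits printed from compound 1 to compound 4 (within the scatter) in this assay and so adds the first reading at this position. The entering group has 5 heavy atoms and one five-membered aromatic ring, while the leaving ethyl has 2 heavy atoms and no ring, so this one change in size and ring count on the thiophene leaves the read-out within the scatter, whereas the earlier step, an at least 2.3-fold lower number from compound 2 to compound 3 (0.36 log units; beyond the scatter), exchanged the whole aromatic group. Compound 2 remains the only entry that is an assay limit, so the new step is a reading between two real numbers and does not involve that entry: the limit of > 100000 nM in this assay, at which 1 of the 4 values shown sits.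

Still open, on these data alone, is whether an amine, a carboxylic acid or a longer chain on this same aromatic carbon would also stay within the scatter of compound 1. A single pair also cannot show whether thiophen-3-yl and ethyl would match in the same way with a different aromatic group on the saturated chain carbon bound to the amine nitrogen.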